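Series notes: allyl for methyl on the amide nitrogen

This account rests on a few compounds, and the source may have more. Where it says the series, first, only, none or still open, it means among the compounds named here.

Three compounds carry numbers in an in vitro ADME assay on microsomes from liver (Homo sapiens) for metabolic stability; a higher number here means that the compound lasts longer, a lower number that the compound disappears faster. Compound 1 `O=C(CSc1nnnn1-c1cccc2ccccc12)Nc1ccccc1[N+](=O)[O-]` gives 0.05 h in this assay. Compound 2 `Cc1ccc(-n2nnnc2SCC(=O)Nc2ccccc2Cl)c(Cl)c1` gives 0.0333 h. Compound 3 `CN(C(=O)CCC(=O)Nc1ccc(-c2ccc(OCC(=O)O)cc2)cc1Cl)c1ccc(C(C)(C)C)cc1Cl` gives 0.9 h, the highest of the three; its nearest neighbour is compound 1, whose number is lower by a margin beyond the scatter, and compound 2 stands further off still, also beyond the scatter. For the measured compounds named here, compounds 1 and 2 share no common core with compound 3, so no single-point step between measured compounds is available.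

Compound 4 `C=CCN(C(=O)CCC(=O)Nc1ccc(-c2ccc(OCC(=O)O)cc2)cc1Cl)c1ccc(C(C)(C)C)cc1Cl` differs from compound 3 in one place only: vinyl in place of hydrogen on a saturated chain carbon bound to an amide-type nitrogen, which read one bond further out is methyl to allyl. Going by the values given here, no measured pair shows this change, so the expectation rests on the size of the structural change alone. The expected step from compound 3 to compound 4 is a 1.5-fold lower number from compound 3 to compound 4 (0.18 log units; within the scatter), a slight decrease that may well stay within the scatter. Compound 4 is therefore estimated at 0.6 h, with a range from 0.2 h to 1.5 h.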

Compound 4, half-life: 0.15 h
Beside the measured number, compound 4's estimate is 4.0-fold (0.60 log units) above it, outside the stated range (below it).
By their numbers in this assay, from the lowest: compounds 2 and 1 (each within the scatter of the next); then compound 4; then compound 3.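

For the compounds shown here, on the amide nitrogen of this core, replacing methyl by allyl gives a 6.0-fold lower number from compound 3 to compound 4 (0.78 log units; beyond the scatter) in this assay, the only single-point step available. The position is therefore not indifferent to a small change: vinyl in place of hydrogen adds only 2 heavy atoms, with 0 hydrogen-bond donors, 0 hydrogen-bond acceptors and no net charge, yet the step lies beyond the scatter. Nothing measured here bears on the origin of this step.

The compounds shown leave open whether the step follows the double bond or the longer chain: propyl on the amide nitrogen, a saturated chain, would separate the two. They also leave open how the amide hydrogen or a cyclopropylmethyl group would read at this position.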